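The source may report more compounds than this note shows. Statements on the series, on what has been measured and on what is new or still open speak of the compounds shown alone.

Within the data shown here, only two compounds have been measured so far in a functional assay on Bel-7402 cells (Homo sapiens) for antiproliferative activity, with a stated time of 72 h; a lower number here means a stronger inhibitor, a higher number a weaker inhibitor. Compound 1 `COc1cc(OC)c(C(=O)/C=C/c2ccccc2Cl)c(O)c1CN(C)CC(=O)O` gives 35200 nM, and compound 2 `COc1cc(O)c2c(=O)cc(-c3ccccc3Cl)oc2c1CN1CCCCC1` gives 118000 nM. Compound 2 therefore has the higher of the two numbers, which makes it the weaker inhibitor, and the gap between them lies beyond the scatter of repeated measurements.

Compound 3 `COc1cc(OC)c2c(=O)cc(-c3ccccc3Cl)oc2c1CN1CCCCC1` differs from compound 2 in one place, methyl in place of hydrogen on an oxygen on an aromatic ring, which turns hydroxy to methoxy. Among the measured compounds shown here, no measured pair shows this change, so the data give no direct guide to its size. In this assay, the expectation is no shift beyond the scatter, with a slight lean towards a lower number. The expected change is a 1.3-fold lower number from compound 2 to compound 3 (0.12 log units; within the scatter). Compound 3 is estimated at 90000 nM, with an expected range from 30000 nM to 220000 nM.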

Compound 3, half-maximal inhibitory concentration: 44200 nM
Compound 3: middle estimate off by 2.0-fold (0.31 log units), on the high side; the measured number falls inside the stated range.
By their numbers in this assay, from the lowest: compounds 1 and 3 (each within the scatter of the next); then compound 2.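

In this assay, among these compounds, the change from hydroxy to methoxy gives a 2.7-fold lower number from compound 2 to compound 3 (0.43 log units; beyond the scatter) and so provides the first reading of a single change in this set, since no earlier pair differed in only one place. It shows that the hydrogen on this oxygen on an aromatic ring is not required for activity here, and that putting methyl in its place goes with a stronger inhibitor, though the step is modest. Nothing available here explains the shift.

The compounds shown leave open whether a longer chain on this oxygen, such as ethyl, would lower the number further, or whether an amine in place of the hydroxy would do the same. They also leave open whether methyl at this oxygen would give a similar step with a different group elsewhere on the shared core.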